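The source may report more compounds than this note shows. Statements on the series, on what has been measured and on what is new or still open speak of the compounds shown alone.

In a functional assay on HL-60 cells (Homo sapiens) for cytotoxicity, read by CCK-8 assay, with a stated time of 24 h (a lower number here means a stronger inhibitor, a higher number a weaker inhibitor), compound 1 (`C=CC(=O)N1C(=O)CC(c2ccc(C)cc2)Sc2ccccc21`) gives 94400 nM, compound 2 (`C=CC(=O)N1C(=O)CC(c2ccc([N+](=O)[O-])cc2)Sc2ccccc21`) gives 107000 nM and compound 3 (`C=CC(=O)N1C(=O)CC(c2ccccc2)Sc2ccccc21`) gives 97400 nM, so compound 3 stands within the scatter of both others. Compound 4 (`C=CC(=O)N1C(=O)CC(c2ccc(C(=O)OC)cc2)Sc2ccccc21`) departs from compound 3 at one place, with methoxycarbonyl in place of hydrogen on an aromatic carbon. Among the measured compounds shown here, three measured steps bear on this change, each a swap of one group on an aromatic carbon: a 1.1-fold higher number from compound 1 to compound 2 (0.05 log units; within the scatter), a 1.0-fold higher number from compound 1 to compound 3 (0.01 log units; within the scatter) and a 1.1-fold lower number from compound 2 to compound 3 (0.04 log units; within the scatter). All three stay within the scatter, although methoxycarbonyl itself has not been measured in this series. The expected result is a 1.0-fold higher number from compound 3 to compound 4 (0.01 log units; within the scatter), which means no step beyond the scatter in this assay. For compound 4 the estimated value is 100000 nM, with an expected range of 60000 nM to 160000 nM.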

Compound 4, half-maximal inhibitory concentration: 102000 nM
For compound 4 the middle estimate is 1.0-fold (0.01 log units) below the measured one, and the stated range covers the measured number.
By their numbers in this assay, from the lowest: compounds 1, 3, 4 and 2 (each within the scatter of the next).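

In this assay, with methoxycarbonyl on this aromatic carbon, para to a large group, a 1.0-fold higher number from compound 3 to compound 4 (0.02 log units; within the scatter) and a 1.0-fold lower number from compound 2 to compound 4 (0.02 log units; within the scatter) and a 1.1-fold higher number from compound 1 to compound 4 (0.03 log units; within the scatter) all lie within the scatter. Hydrogen, methyl, nitro and methoxycarbonyl at this place thus give numbers that cannot be told apart, and the new group, the first here to carry a carbonyl, does not alter that picture. No measurement at hand speaks to a cause for this. Open, as far as these compounds go, is whether an amine, a carboxylic acid or a longer chain at this carbon would stay within the scatter. Also open, from the compounds shown here alone, is whether changes elsewhere on the shared core would move the number.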